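A few compounds are considered here, and "the series" means these few. Any claim that something is new, unique, unknown or untested is made for them only; others in the source may bear on it.

Measured so far:
compound 1, `COc1ncc(-c2ccc3c(c2)N(c2ccc(C)cc2)C(=O)CO3)cc1NS(=O)(=O)c1ccc(F)cc1` — 28300 nM
compound 2, `COc1cccc(N2C(=O)COc3ccc(-c4cnc5ccccc5c4)cc32)c1` — 2080 nM
compound 3, `CC(C)N1C(=O)COc2ccc(-c3cnc(Cl)c(NS(=O)(=O)c4ccc(F)cc4)c3)cc21` — 21500 nM

In a functional assay on HepG2 cells (Homo sapiens) for antiproliferative activity, read by MTT assay, with a stated time of 72 h (on this read-out lower numbers stand for stronger inhibition and higher numbers for weaker inhibition), compound 1 gives the highest of the three numbers. Compound 3 stands nearest to it, with a value that lies within the scatter of compound 1, so the two cannot be ordered. Compound 2 stands furthest away, with a value well beyond the scatter, and so is clearly the more potent of that pair.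

The account now turns to compound 4, `COc1ncc(-c2ccc3c(c2)N(C2CCCCC2)C(=O)CO3)cc1NS(=O)(=O)c1ccc(F)cc1`, which has not yet been measured in this assay. It differs from compound 1 in one place: cyclohexyl in place of 4-methylphenyl on an amide-type nitrogen in a ring. Among the compounds with values here, no step between two measured compounds isolates this change, so the expectation rests on the level of compound 1 itself, 28300 nM, and on the fact that compound 3, which carries a small alkyl group on the same ring nitrogen, gives 21500 nM, a number not separated from compound 1 by more than the scatter.

Compound 4 is therefore expected to lie close to compound 1, with at most a modest shift, estimated as a 1.4-fold lower number from compound 1 to compound 4 (0.15 log units; within the scatter). The estimate for compound 4 is 20000 nM, with a range from 6000 nM to 60000 nM.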

Compound 4, half-maximal inhibitory concentration: > 40000 nM
Compound 4 gave a limit, no number (the forecaster's own chance of this, stated with the estimate: 10%); at least 2.0-fold (0.30 log units) between middle value and limit.
By their numbers in this assay, from the lowest: compound 2; then compounds 3 and 1 (each within the scatter of the next). At a limit, above all of these: compound 4.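

In this assay, compound 4 gives no number, only a limit: the limit of > 40000 nM in this assay, at which 1 of the 4 values shown sits.

Exchanging 4-methylphenyl for cyclohexyl on the amide-type nitrogen in a ring gives an at least 1.4-fold higher number from compound 1 to compound 4 (0.15 log units; that floor lies within the scatter). This shows that the non-aromatic ring brings no gain at this position, although the floor of the step alone does not establish a real loss.

Going by these compounds, how far compound 4 lies past its limit remains open, so the size of the effect of this change cannot be read. Also open, on these data alone, is how this core would respond if the ring nitrogen carried a substituent with an amine or a carboxylic acid, or a longer chain in place of either six-membered ring.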